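From Carboxyphenyl to Methoxybenzyl on a Glucoside Triazole

The compounds below may be only part of what the source reports. "The series", "measured", "known", "first", "only" and "open" are said of these compounds alone.

Compound 1 `O=C(O)c1ccc(-n2cc(CO[C@H]3O[C@H](CO)[C@@H](O)[C@H](O)[C@@H]3O)nn2)cc1` was measured in a physicochemical assay for solubility, read by LC-MS, using the shake flask method, measured as thermodynamic solubility, with a stated time of 24 h, at pH 6.5; a higher number here means a more soluble compound, a lower number a less soluble compound. In this assay compound 1 gives > 3000 ug/mL, which is a limit of the assay and not a number. Compound 2 `O=C(O)c1cccc(-n2cc(CO[C@H]3O[C@H](CO)[C@@H](O)[C@H](O)[C@@H]3O)nn2)c1` differs from compound 1 only as 3-carboxyphenyl in place of 4-carboxyphenyl on an aromatic nitrogen. In this assay compound 2 gives > 3000 ug/mL, again a limit rather than a number. The step that the two limits leave unreadable from compound 1 to compound 2 is therefore of unreadable size. Both values sit at the limit of > 3000 ug/mL in this assay, at which 2 of the 2 values shown sit, so compound 1 stands at the limit itself, with no measured value to place it beyond that.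

Compound 3 `COc1ccc(Cn2cc(CO[C@H]3O[C@H](CO)[C@@H](O)[C@H](O)[C@@H]3O)nn2)cc1` has not yet been measured in this assay. It differs from compound 1 as 4-methoxybenzyl in place of 4-carboxyphenyl on an aromatic nitrogen. Going by the values given here, the only measured step, from compound 1 to compound 2, exchanges one carboxyphenyl for another and offers nothing readable for a change of this kind, so no size of step can be drawn from the data. The account nonetheless expects compound 3 to return a number rather than a limit, estimated at 800 ug/mL, within the range 150 ug/mL to 3000 ug/mL. The step this estimate means is an at least 3.7-fold lower number from compound 1 to compound 3 (0.57 log units; beyond the scatter), stated as an expectation only.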

Compound 3, solubility: > 3000 ug/mL
Compound 3: no number, only a limit; the forecaster's own chance of this, stated with the estimate: 30%; middle value at least 3.7-fold (0.57 log units) from the limit.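

Compound 3 also returns a limit and not a number, so no step among compound 1, compound 2 and compound 3 can be read in this assay: the limit of > 3000 ug/mL in this assay, at which 3 of the 3 values shown sit.

The compounds shown leave open how compound 1, compound 2 and compound 3 rank in solubility, and whether 4-methoxybenzyl in place of 4-carboxyphenyl changes the read-out at all.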